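Swapping the cyano for fluoro on a shared core

The compounds below may be only part of what the source reports. "The series", "measured", "known", "first", "only" and "open" are said of these compounds alone.

Measured so far:
compound 1, `Cc1ncccc1-c1cnc(NCc2c(F)cc(Cl)c3c2CCO3)n2cnnc12`, 9 uL/min in an ADME assay on cells (Hepatocyte, Rattus norvegicus) for metabolic stability; a higher number here means faster removal of the compound, a lower number slower removal
compound 2, `Cc1ncccc1-c1cnc(NCc2c(F)cc(C#N)c3c2CCO3)n2cnnc12`, 10 uL/min in this assay

Compound 2 shows the higher of the two numbers in this assay, but the step is a 1.1-fold higher number from compound 1 to compound 2 (0.05 log units; within the scatter), so the two stand together. Compound 3 is `Cc1ncccc1-c1cnc(NCc2c(F)cc(F)c3c2CCO3)n2cnnc12`; the change is fluoro in place of cyano on an aromatic carbon. For the measured compounds named here, the only step that bears on it, cyano in place of chloro at the same aromatic carbon, was a 1.1-fold higher number from compound 1 to compound 2 (0.05 log units; within the scatter). With the same site changing again and no step beyond the scatter on record, the expectation is no real change: compound 3 is estimated at 10 uL/min, ranging from 5 uL/min to 20 uL/min, a step of no change at the digits printed from compound 2 to compound 3 (within the scatter).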

Compound 3, intrinsic clearance in a liver preparation (reported as CLH), per the amount of preparation that the assay uses: 9 uL/min
Compound 3: middle estimate off by 1.1-fold (0.05 log units), on the high side; the range from low to high includes it.
By their numbers in this assay, from the lowest: compounds 1, 3 and 2 (each within the scatter of the next).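

In this assay the fluoro group at this aromatic carbon gives a 1.1-fold lower number from compound 2 to compound 3 (0.05 log units; within the scatter) and also no change at the digits printed from compound 1 to compound 3 (within the scatter). Chloro, cyano and fluoro, the three groups shown at this place, therefore stand together, and even the step from the two heavy atoms of cyano to the single heavy atom of fluoro stays within the scatter. No measurement shown here offers an explanation for this. On these data alone, whether an amine, a carboxylic acid or a longer chain at this carbon would give a step beyond the scatter remains open. So does whether other places on the shared core behave the same way.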